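Removing the Sugar-like Group from a Gastric Inhibitor

This account rests on a few compounds, and the source may have more. Where it says the series, first, only, none or still open, it means among the compounds named here.

Measured so far:
Compound 1 `COc1ccnc(CNc2ccc3c(c2)nc(C)n3C[C@@H](O)[C@H]2O[C@H](O)[C@@H](O)[C@H]2O)c1OC`: 61%
Compound 2 `COc1ccnc(CNc2ccc3c(c2)nc(C)n3C[C@@H](O)[C@H]2O[C@H](O)[C@@H](O)[C@H]2O)c1C`: 57.9%

Compound 1 was tested in a functional assay on the whole organism (stomach, strain Swiss albino) for inhibition, with Mus musculus as the target, with a stated time of 3 days, at a dose of 3.6 mg/kg by the oral route (a higher number here means a stronger effect of the compound at the dose given, a lower number a weaker effect), and gave 61%. Compound 2 differs from it by a methyl in place of a methoxy on an aromatic carbon, and the step of a number 3.1 percentage points lower from compound 1 to compound 2 (within the scatter) is within the scatter, so the two compounds cannot be told apart on these numbers.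

Compound 3 `COc1ccnc(CNc2ccc3[nH]c(C)nc3c2)c1OC` has not been measured. Compared with compound 1, (a hydrogen atom in place of a group of 11 heavy atoms (6 carbon, 5 oxygen; one five-membered non-aromatic ring with 1 hetero atom), on an aromatic nitrogen). Going by the values given here, the only measured step concerns a different place, the methoxy-to-methyl swap on the aromatic carbon, and says nothing about what happens when this large group on the aromatic nitrogen is replaced by hydrogen. No direction can be supported from the data.

Compound 3 is therefore estimated at 65%, with a wide range from 35% to 90%, which means an expected step of a number 4 percentage points higher from compound 1 to compound 3 (within the scatter).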

Compound 3, a percentage reported as inhibition, in the whole organism at one dose (the size of the read-out at that dose, not a potency): 30%
For compound 3 the middle estimate is 35 percentage points above the measured one; measured number below the stated range.
By their numbers in this assay, from the lowest: compound 3; then compounds 2 and 1 (each within the scatter of the next).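

In this assay, a hydrogen atom in place of the group of 11 heavy atoms on the aromatic nitrogen gives a number 31 percentage points lower from compound 1 to compound 3 (beyond the scatter), so the effect at this dose depends strongly on what sits at this position, something the methoxy-to-methyl swap elsewhere on the molecule could not reveal. The group is not the whole story, though, since with the rest of compound 1 kept and the group gone, compound 3 still gives 30%. Nothing available here explains why removing the group has this result.

Going by these compounds, it remains open whether the entire group is needed or whether a smaller substituent on the same aromatic nitrogen, such as a methyl group or a short hydroxyethyl chain, would restore the effect. It is also unclear whether the five-membered non-aromatic ring itself matters, or only its hydroxyl groups.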